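Swapping the Ring-Nitrogen Substituent: Thiocarbonyl to Carbonyl

A few compounds are considered here, and "the series" means these few. Any claim that something is new, unique, unknown or untested is made for them only; others in the source may bear on it.

Measured so far:
- compound 1, `COc1cc(C2=NN(S(=O)(=O)c3ccc(C)cc3)C(c3ccc(Cl)cc3)C2)ccc1O`: 40000 nM
- compound 2, `COc1cc(C2=NN(C(=S)Nc3ccccc3)C(c3ccc(Cl)cc3)C2)ccc1O`: 19600 nM

Both compounds share the same core and were tested in an assay on isolated protein for inhibition of Amine oxidase [flavin-containing] A (Homo sapiens), read by fluorescence and Amplex Red, with a stated time of 30 min; on this read-out higher numbers stand for weaker inhibition and lower numbers for stronger inhibition. Compound 2 gives 19600 nM and stands at the lowest of the two numbers, the nearest being compound 1, with a 2.0-fold lower number from compound 1 to compound 2 (0.31 log units; beyond the scatter).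

Compound 3, `COc1cc(C2=NN(C(=O)Oc3ccccc3)C(c3ccc(Cl)cc3)C2)ccc1O`, has not yet been measured. Compared with compound 2 it carries a group of 9 heavy atoms (7 carbon, 2 oxygen; one six-membered aromatic ring of carbon only) in place of a group of 9 heavy atoms (7 carbon, 1 nitrogen, 1 sulfur; one six-membered aromatic ring of carbon only), on an amine nitrogen in a ring. The group that leaves has one hydrogen-bond donor and one acceptor; the phenoxycarbonyl that enters has no donor and two acceptors.

For the measured compounds named here, only one measured step exists, and it concerns a different exchange on the same ring nitrogen: a 2.0-fold lower number from compound 1 to compound 2 (0.31 log units; beyond the scatter). That step shows the ring-nitrogen substituent can shift the number modestly, but it does not cover a phenoxycarbonyl. Going by the values given here, with no closer precedent, the expected step in this assay is small, toward a somewhat higher number, and may fall within the scatter.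

For compound 3 the estimated value in this assay is 26000 nM, with a range from 10000 nM to 65000 nM, which amounts to an expected 1.3-fold higher number from compound 2 to compound 3 (0.12 log units; within the scatter).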

Compound 3, inhibition constant: 193000 nM
Compound 3: the middle estimate sits 7.4-fold (0.87 log units) below what was measured; measured number outside the range, above it.
By their numbers in this assay, from the lowest: compound 2; then compound 1; then compound 3.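

In this assay the group on the ring nitrogen proves able to move the number much further than the first pair showed, where the exchange gave only a 2.0-fold lower number from compound 1 to compound 2 (0.31 log units; beyond the scatter). Putting phenoxycarbonyl in place of the group of compound 2, which holds a nitrogen and a sulfur, gives a 9.8-fold higher number from compound 2 to compound 3 (0.99 log units; beyond the scatter), even though both groups have the same count of heavy atoms and each carries a phenyl ring. Phenoxycarbonyl also compares poorly with (4-methylphenyl)sulfonyl, at a 4.8-fold higher number from compound 1 to compound 3 (0.68 log units; beyond the scatter), which makes compound 3 the weakest inhibitor of the three, and no separate measurement accounts for these steps.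

The exchange from compound 2 to compound 3 alters two things together, the thiocarbonyl becoming a carbonyl and the linking nitrogen becoming an oxygen, so the compounds shown cannot say which of the two matters more. A phenylaminocarbonyl group, which keeps the linking nitrogen but carries a carbonyl, would separate these two changes, and an acetyl group would show whether the phenyl ring is needed at this position at all.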